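Aryl variation at the pyridine-linked position of a glucagon receptor series

The source may hold more compounds than are shown below. What is called first, only, known or untested is meant among the compounds shown, and "the series" means these compounds.

Of the compounds shown here, three sharing one core have been measured in an assay on CHO cells for inhibition of Glucagon receptor (Homo sapiens), tested at 20 uM; a lower number here means less inhibition, a higher number more inhibition at the concentration tested (going by the name of the read-out). Compound 1 `CCCCCc1c(C(C)C)nc(C(C)C)c(CO)c1-c1ccc(CC)cc1` gives 42%, compound 2 `CCCCCc1c(C(C)C)nc(C(C)C)c(CO)c1-c1ccc(O)cc1` gives 24%, and compound 3 `CCCCCc1c(C(C)C)nc(C(C)C)c(CO)c1-c1ccccc1C` gives 33%. Within the data shown here, compound 3 stands second of the three: the step of a number 9 percentage points lower from compound 1 to compound 3 (within the scatter) and the step of a number 9 percentage points higher from compound 2 to compound 3 (within the scatter) both lie within the scatter, whereas a number 18 percentage points lower from compound 1 to compound 2 (beyond the scatter) is the one change that exceeds it. Compound 4 `CCCCCc1c(C(C)C)nc(C(C)C)c(CO)c1-c1ccc(Cl)cc1Cl` is not yet measured; its change from compound 3 is 2,4-dichlorophenyl in place of 2-methylphenyl on an aromatic carbon. Among the measured compounds shown here, no measured step concerns a dichlorophenyl, but the two aryl replacements that exclude the hydroxy stayed within the scatter, so the expected step is a number 7 percentage points higher from compound 3 to compound 4 (within the scatter), none beyond the scatter. The estimate for compound 4 is therefore 40%, ranging from 20% to 60%.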

Compound 4, a percentage reported as inhibition, at one concentration (the size of the read-out at that concentration, not a potency): 8%
Compound 4: the middle estimate sits 32 percentage points above what was measured; measured number below the stated range.
By their numbers in this assay, from the lowest: compound 4; then compounds 2, 3 and 1 (each within the scatter of the next, the first and the last beyond it).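

At this position, opposite the ring nitrogen, the 2,4-dichlorophenyl group gives a number 25 percentage points lower from compound 3 to compound 4 (beyond the scatter) and a number 16 percentage points lower from compound 2 to compound 4 (beyond the scatter) and also a number 34 percentage points lower from compound 1 to compound 4 (beyond the scatter) in this assay. The aryl group here can therefore move the number beyond the scatter even without a hydroxy, and this change places compound 4 beyond the scatter of every earlier compound. No evidence on the reason for this drop is at hand. Going by these compounds, whether a single chlorine on the phenyl would give the same drop stays open. So does how a phenyl carrying an amine or a carboxylic acid would read.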